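A few compounds are considered here, and "the series" means these few. Any claim that something is new, unique, unknown or untested is made for them only; others in the source may bear on it.

Measured in a physicochemical assay for solubility, at pH 7; a higher number here means a more soluble compound, a lower number a less soluble compound:
- compound 1 `CC(C)(C)C(=O)N1Cc2c(NC(=O)c3cccnc3)n[nH]c2C1(C)C` gives 207000 nM
- compound 2 `CN1CCC(C(=O)N2Cc3c(NC(=O)NCc4ccccc4)n[nH]c3C2(C)C)CC1` gives > 225000 nM (a limit, not a number)
- compound 3 `CN1CCC(C(=O)N2Cc3c(NC(=O)c4ccsc4)n[nH]c3C2(C)C)CC1` gives > 225000 nM (a limit, not a number)

Among the measured compounds shown here, compound 1 holds the only true number here, so its rank against the other two cannot be read. Compound 4 `CN(C)CC(=O)Nc1n[nH]c2c1CN(C(=O)C(C)(C)C)C2(C)C` differs from compound 1 as follows: (dimethylamino)methyl in place of pyridin-3-yl on a carbonyl carbon. For the measured compounds named here, the data show the limit of > 225000 nM in this assay, at which 2 of the 3 values shown sit, and the one measured step, also on a carbonyl carbon, is a step that the two limits leave unreadable from compound 2 to compound 3, so no measured size carries over. The expectation therefore rests on compound 1 at 207000 nM and foresees no change beyond the scatter in this assay, in either direction. The expected step is a 1.0-fold higher number from compound 1 to compound 4 (0.02 log units; within the scatter) and a report of only a limit is quite possible. For compound 4 the estimate is 215000 nM, with an expected range from 140000 nM to 260000 nM.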

Compound 4, solubility: > 225000 nM
Compound 4 ended at the assay's limit (the forecaster's own chance of this, stated with the estimate: 65%); middle value at least 1.0-fold (0.01 log units) away from the limit.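

In this assay compound 4 gives > 225000 nM, which is a limit and not a number. With (dimethylamino)methyl in place of pyridin-3-yl on a carbonyl carbon, only a floor can be read: an at least 1.0-fold higher number from compound 1 to compound 4 (0.03 log units; that floor lies within the scatter). Unlike the earlier pair, this step has one true number at one end, and it shows that a group with no ring at this place still reaches the limit: the limit of > 225000 nM in this assay, at which 3 of the 4 values shown sit.

As far as these compounds go, the true size of the step stays open. So does whether a carboxylic acid or a longer chain on this carbonyl carbon would give a readable number.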